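The source may hold more compounds than are shown below. What is called first, only, known or untested is meant among the compounds shown, and "the series" means these compounds.

Measured so far:
- compound 1 `CCCCc1cn(C[C@H](O)[C@H]2OC(=O)C(OCc3ccccc3)=C2OCc2ccccc2)nn1`: in a functional assay on CFPAC-1 cells (Homo sapiens) for antiproliferative activity, read by MTT assay, with a stated time of 72 h (on this read-out higher numbers stand for weaker inhibition and lower numbers for stronger inhibition), compound 1 gives 73200 nM
- compound 2 `O=C1O[C@H]([C@@H](O)Cn2cc(CNS(=O)(=O)c3ccc(Cl)cc3)nn2)C(OCc2ccccc2)=C1OCc1ccccc1`: in this assay compound 2 gives 38900 nM

Among the compounds with values here, compound 2 has the lowest of the two numbers, but its only neighbour is compound 1, and the step of a 1.9-fold lower number from compound 1 to compound 2 (0.27 log units; within the scatter) lies within the scatter, so the two compounds cannot be told apart on these data.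

Compound 3 `O=C1O[C@H]([C@@H](O)Cn2cc(-c3cc(F)cc(F)c3)nn2)C(OCc2ccccc2)=C1OCc1ccccc1` is not yet measured in this assay. It differs from compound 2 in one place: 3,5-difluorophenyl in place of (((4-chlorophenyl)sulfonyl)amino)methyl on an aromatic carbon. Within the data shown here, the only step measured so far, a 1.9-fold lower number from compound 1 to compound 2 (0.27 log units; within the scatter), concerns a change at the same position of the shared core and did not move the number beyond the scatter. Among the measured compounds shown here, no step measured here exchanges a sulfonamide-bearing side chain for an aryl group bound directly to the ring, so there is no direct precedent for this change. On that basis a step of no more than the scatter is expected, in either direction, a 1.2-fold higher number from compound 2 to compound 3 (0.06 log units; within the scatter). Compound 3 is therefore estimated at 45000 nM in this assay, with a range from 10000 nM to 150000 nM.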

Compound 3, half-maximal inhibitory concentration: 62400 nM
Compound 3: middle estimate off by 1.4-fold (0.14 log units), on the low side; the range from low to high includes it.
By their numbers in this assay, from the lowest: compounds 2, 3 and 1 (each within the scatter of the next).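

The position has now taken three quite different groups, and this assay does not separate them: 3,5-difluorophenyl in place of (((4-chlorophenyl)sulfonyl)amino)methyl gives a 1.6-fold higher number from compound 2 to compound 3 (0.21 log units; within the scatter), and 3,5-difluorophenyl in place of butyl gives a 1.2-fold lower number from compound 1 to compound 3 (0.07 log units; within the scatter), so neither exchange can be read as a real change. Beyond what the earlier pair showed, an aromatic ring bound directly to the aromatic carbon of the five-membered ring, with no chain in between, also stays within the scatter of both a group with a hydrogen-bond donor and acceptors and a plain alkyl chain, although 3,5-difluorophenyl has 0 hydrogen-bond donors and 0 hydrogen-bond acceptors. Nothing available explains why these three groups cannot be told apart.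

On these data alone, whether an amine, a carboxylic acid or a longer chain on this aromatic carbon would move the number beyond the scatter remains open, as does the reading for a plain phenyl group without the two fluorines. The three compounds also share the rest of the core unchanged, so they leave open whether changes elsewhere on it would matter more than changes at this position.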